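Dropping the Pyrazine Ether Arm: Expected Cytotoxicity Shift

The source may report more compounds than this note shows. Statements on the series, on what has been measured and on what is new or still open speak of the compounds shown alone.

Three compounds have been measured in a functional assay on SH-SY5Y cells (Homo sapiens) for cytotoxicity, read by MTT assay, with stated times of 24 h and 4 h; on this read-out lower numbers stand for an effect already at smaller amounts and higher numbers for an effect only at larger amounts of compound:
compound 1 `COc1cc(/C=C/C(=O)NCc2ccc(OCc3nc(C)c(C)nc3C)c(OC)c2)ccc1OCc1nc(C)c(C)nc1C` gives 11100 nM;
compound 2 `COc1cc(CNC(=O)/C=C/c2ccc(OC)c(OCc3nc(C)c(C)nc3C)c2)ccc1O` gives 9250 nM;
compound 3 `COc1cccc(/C=C/C(=O)NCc2ccc(OCc3nc(C)c(C)nc3C)c(OC)c2)c1` gives 4320 nM.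

Compound 3 differs from compound 1 in one place, (hydrogen in place of (3,5,6-trimethylpyrazin-2-yl)methoxy on an aromatic carbon). That change gave a 2.6-fold lower number from compound 1 to compound 3 (0.41 log units; beyond the scatter). Compound 2 and compound 1 share much of their structure, but how their two cores differ is not broken down here; their two numbers lie within the usual scatter of each other, so no order can be read from them.

Compound 4 `COc1ccc(/C=C/C(=O)NCc2ccc(O)c(OC)c2)cc1` has not yet been measured. It stands to compound 2 as compound 3 stands to compound 1: hydrogen in place of (3,5,6-trimethylpyrazin-2-yl)methoxy on an aromatic carbon. The surroundings are not identical, since the site is para to a large group in compound 1 but meta to a large group in compound 2, so this is the same kind of change rather than the same change. Because the earlier change showed a 2.6-fold lower number from compound 1 to compound 3 (0.41 log units; beyond the scatter) a step of comparable size is expected here, a 2.1-fold lower number from compound 2 to compound 4 (0.31 log units; beyond the scatter). Compound 4 is therefore estimated at 4500 nM, with a likely range from 2500 nM to 9000 nM.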

Compound 4, half-maximal effective concentration: 11400 nM
Compound 4: the middle estimate sits 2.5-fold (0.40 log units) below what was measured, and the stated range ends below it.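

In this assay, replacing the (3,5,6-trimethylpyrazin-2-yl)methoxy group with hydrogen on the core of compound 2 gave a 1.2-fold higher number from compound 2 to compound 4 (0.09 log units; within the scatter), so compound 4 cannot be told apart from compound 2 on this read-out. The result from one core therefore did not carry over to the other, and the gap between the two steps is larger than chance scatter would readily explain: the same change on two cores in this assay, a 2.6-fold lower number (0.41 log units; beyond the scatter) from compound 1 to compound 3 and a 1.2-fold higher number (0.09 log units; within the scatter) from compound 2 to compound 4, 3.2-fold (0.50 log units) apart, beyond the scatter of two such steps This shows that the effect of removing the group depends on its surroundings in this series, but it does not show which structural difference between the two cores is responsible, and two pairs cannot predict what a third core would do.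

The compounds shown leave open what an amine or a carboxylic acid would do at this site on either core, since only hydrogen and the (3,5,6-trimethylpyrazin-2-yl)methoxy group are compared there. A longer chain joining that same ring to the oxygen would also be untested here.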